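A few compounds are considered here, and "the series" means these few. Any claim that something is new, unique, unknown or untested is made for them only; others in the source may bear on it.

Measured compounds:
Compound 1 `Cc1cccc(-n2nncc2CN2C(=O)C3(C(C#N)=C(N)Oc4c3c3nc5ccccc5nc3c3ccccc43)c3ccccc32)c1` in a functional assay on A549 cells (Homo sapiens) for antiproliferative activity, read by MTT assay, with a stated time of 48 h (a higher number here means a weaker inhibitor, a lower number a stronger inhibitor), gives 39600 nM.
Compound 2 `N#CC1=C(N)Oc2c(c3nc4ccccc4nc3c3ccccc23)C12C(=O)N(Cc1cnnn1-c1ccccc1Br)c1ccccc12` in this assay gives > 50000 nM, which is a limit of the assay and not a number.

Within the data shown here, compound 1 stands as the only compound with a numerical value in this assay; the one other value shown is a limit (the limit of > 50000 nM in this assay, at which 1 of the 2 values shown sits). The unmeasured compound 3 `N#CC1=C(N)Oc2c(c3nc4ccccc4nc3c3ccccc23)C12C(=O)N(Cc1cnnn1-c1cc(Cl)ccc1Cl)c1ccccc12` differs from compound 1 in one place: 2,5-dichlorophenyl in place of 3-methylphenyl on an aromatic nitrogen. Among the measured compounds shown here, the one measured step that bears on this change is an at least 1.2-fold higher number from compound 1 to compound 2 (0.10 log units; that floor lies within the scatter), where 2-bromophenyl replaced 3-methylphenyl on the aromatic nitrogen and the result sat at a limit of the assay (the limit of > 50000 nM in this assay, at which 1 of the 2 values shown sits). That step gives only a floor, and the floor lies within the scatter, so its size is uncertain, but it points to no gain from exchanging the methylphenyl for a halogenated phenyl at this position. Compound 3 is therefore expected to land at or past the limit of this assay, with an expected step of a 1.3-fold higher number from compound 1 to compound 3 (0.10 log units; within the scatter). The estimate for compound 3 is 50000 nM, with a range from 25000 nM to 100000 nM, and a fair chance that this assay reports only a limit.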

Compound 3, half-maximal inhibitory concentration: > 50000 nM
Compound 3 was reported as a limit; the forecaster's own chance of this, stated with the estimate: 55%; the middle value lies on the limit itself.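

In this assay, a second halogenated phenyl on the aromatic nitrogen again brings no measurable gain over 3-methylphenyl: the change to 2,5-dichlorophenyl gives an at least 1.2-fold higher number from compound 1 to compound 3 (0.10 log units; that floor lies within the scatter). From the compounds shown here alone, with 2-bromophenyl and 2,5-dichlorophenyl both failing to give a lower number, the earlier result no longer rests on a single group, although the size of each rise remains unknown and the floor printed for this step does not establish a real loss. Compound 2 and compound 3 both stand at a limit of the assay, which is not a number, so the step between them cannot be read and the two halogenated groups cannot be ranked against each other: the limit of > 50000 nM in this assay, at which 2 of the 3 values shown sit.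

The compounds shown carry only methyl, bromine and chlorine on this phenyl ring, so it remains open whether any group there could give a clearly lower number than the one for compound 1. Going by these compounds, what an amine, a carboxylic acid or a longer chain on that ring would do in this assay also remains open.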